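Swapping an Ethoxy for a Formyl on the Shared Core

The compounds below may be only part of what the source reports. "The series", "measured", "known", "first", "only" and "open" are said of these compounds alone.

Compound 1 `CCOc1ccccc1OC(C)C1=NCCN1` was tested in a functional assay on CHO cells for agonist activity at Alpha-2B adrenergic receptor (Homo sapiens) (a lower number here means that less compound is needed, a higher number that more compound is needed for the effect), where compound 1 gives 3160 nM. Going by the values given here, this is the lowest of the two numbers measured so far. Among the compounds with values here, its only neighbour, compound 2 `CC(Oc1ccccc1OC1CC1)C1=NCCN1`, gives 12900 nM in this assay. Within the data shown here, the one step that connects them, a 4.1-fold higher number from compound 1 to compound 2 (0.61 log units; beyond the scatter), shows that changing the group on the ring oxygen moves the number noticeably.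

Compound 3 `CC(Oc1ccccc1C=O)C1=NCCN1` has not been measured. It differs from compound 1 as follows: formyl in place of ethoxy on an aromatic carbon. The measured step from compound 1 to compound 2 concerns the same side of the shared core, but there the oxygen stayed and only its substituent grew; here the ethoxy is removed altogether and a formyl takes its place. That step is therefore only a loose guide, and it hints that alterations at this spot tend to raise the number rather than lower it.

For compound 3 the estimate in this assay is 6000 nM, within a range from 1500 nM to 25000 nM. This expected step, a 1.9-fold higher number from compound 1 to compound 3 (0.28 log units; within the scatter), is modest and uncertain.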

Compound 3, half-maximal effective concentration: 316 nM
Compound 3: middle estimate off by 19-fold (1.28 log units), on the high side; measured number below the stated range.
By their numbers in this assay, from the lowest: compound 3; then compound 1; then compound 2.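

Going by these compounds alone, until now, the only change at this position, on the ring oxygen, had raised the number, but replacing the whole ethoxy with a formyl in this assay gives a 10-fold lower number from compound 1 to compound 3 (1.00 log units; beyond the scatter), so this position can also move the number down. Measured against the cyclopropyloxy group, the same formyl gives a 41-fold lower number from compound 2 to compound 3 (1.61 log units; beyond the scatter), which places the three groups in a clear order at this one spot: formyl gives the lowest number, ethoxy the next and cyclopropyloxy the highest. The swap from ethoxy alters several things at once, since it removes the oxygen attached to the ring, shortens the group by the heavy-atom count and brings in a double bond outside aromatic rings, so the result cannot be pinned on any one of these features.

No supporting data are available to explain why the number falls with the formyl. Still open, going by these compounds, is whether a low number also comes with related groups at this position, such as an acetyl, a nitrile or a carboxylic acid, or whether it is particular to the formyl.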